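The compounds below may be only part of what the source reports. "The series", "measured", "known", "first", "only" and "open" are said of these compounds alone.

Measured compounds:
compound 1, `C=C1CCCC(C)(C)[C@@H]1CC/C(C)=C/C(=O)NC(=N)NC(=O)C=C(C)C`, 29400 nM
compound 2, `CC(C)=CCC/C(C)=C/CC/C(C)=C/C(=O)NC(=N)NC(=O)C=C(C)C`, 23400 nM
compound 3, `CC(C)=CC(=O)NC(=N)NC(=O)C=C(C)C`, 75600 nM

All three are acylguanidines carrying the same 3-methylbut-2-enoyl group on one side and differing on the other. In a functional assay on A549 cells (Homo sapiens) for inhibition, read by MTT assay, with a stated time of 72 h (a lower number here means a stronger inhibitor of growth, a higher number a weaker inhibitor of growth), compound 3 gives 75600 nM, the highest number of the three; compound 1 gives 29400 nM and compound 2 gives 23400 nM, both beyond the scatter from compound 3 in the lower direction.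

Compound 4, `CC(C)=CCC/C(C)=C/C(=O)NC(=N)NC(=O)C=C(C)C`, is not yet measured. It differs from compound 3 by 3-methylbut-2-en-1-yl in place of hydrogen on a saturated chain carbon bound to a double-bonded chain carbon. The two compounds carrying a longer chain on that side, compound 1 and compound 2, both sit below compound 3 in this assay, so the step from compound 3 to compound 4 is expected to go toward a lower number, of a size near the edge of the scatter. The number for compound 4 in this assay is estimated at 40000 nM, with a range from 20000 nM to 80000 nM, which corresponds to an expected step of a 1.9-fold lower number from compound 3 to compound 4 (0.28 log units; within the scatter).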

Compound 4, concentration for 50% growth inhibition: 37400 nM
For compound 4 the middle estimate is 1.1-fold (0.03 log units) above the measured one; the measured number falls inside the stated range.
By their numbers in this assay, from the lowest: compounds 2, 1 and 4 (each within the scatter of the next); then compound 3.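

In this assay, among these compounds, 3-methylbut-2-en-1-yl in place of hydrogen on a saturated chain carbon bound to a double-bonded chain carbon gives a 2.0-fold lower number from compound 3 to compound 4 (0.31 log units; beyond the scatter) as the first single-place step, modest but beyond the scatter. Read from the longer chain, the same place gives a 1.6-fold higher number from compound 2 to compound 4 (0.20 log units; within the scatter) and stays within the scatter, so compound 2 and compound 4 cannot be told apart in this read-out. No measurement shown accounts for either step.

Going by these compounds, it remains open whether a saturated hexyl chain or a shorter ethyl group at this place would give a step of similar size. Also open, on these data alone, is whether a hydroxyl group, an amine or a carboxylic acid at the chain end would preserve the step from compound 3 to compound 4.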